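Swapping isopropylamino for methyl(phenyl)amino on compound 3

The compounds below may be only part of what the source reports. "The series", "measured", "known", "first", "only" and "open" are said of these compounds alone.

In a functional assay on L02 cells (Homo sapiens) for inhibition, read by Griess assay, with stated times of 1 h and 24 h (a higher number here means a weaker inhibitor, a lower number a stronger inhibitor), compound 1 `CCCc1nn(C)c2c(NC(C)C)nc(/C=C/c3ccc[n+]([O-])c3)nc12` gives 324000 nM as a measured number. Compound 2 `COc1cc(/C=C/c2nccc(NC(C)C)n2)cc(OC)c1OC` gives < 40000 nM as a limit of the assay and not a number. Compound 3 `CC(C)Nc1nc(/C=C/c2ccccc2)nc2ccsc12` gives > 1000000 nM as a limit too, so its standing in this assay is known only as a limit. Compound 4 `CN(c1ccccc1)c1nc(/C=C/c2ccccc2)nc2ccsc12` has methyl(phenyl)amino in place of isopropylamino on an aromatic carbon and has not been measured. Within the data shown here, no measured pair shows what such a swap does, so only a modest move toward stronger inhibition is expected, an estimated at least 1.4-fold lower number from compound 3 to compound 4 (0.15 log units; that floor lies within the scatter) in all. For compound 4 the estimated value is 700000 nM with an expected range from 150000 nM to 2000000 nM in this assay.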

Compound 4, half-maximal inhibitory concentration: > 1000000 nM
Compound 4 gave a limit, no number; the forecaster's own chance of this, stated with the estimate: 50%; at least 1.4-fold (0.15 log units) between middle value and limit.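

Among these compounds, compound 3 and compound 4 both stand only as limits of the assay, so no step between them can be read. The compounds shown leave open whether methyl(phenyl)amino in place of isopropylamino changes inhibition at all.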